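Ring Amine on a Shorter Chain at the Indole Nitrogen

The source may report more compounds than this note shows. Statements on the series, on what has been measured and on what is new or still open speak of the compounds shown alone.

The series shares one core and varies only the chain carried on its aromatic nitrogen. Compound 1 `CN(C)CCCCCn1c2c(c3ccccc31)C(=O)c1c[n+]([O-])c3ccccc3c1C2=O` gives 560 nM in a functional assay on A-375 cells (Homo sapiens) for cytotoxicity, read by MTT assay, with a stated time of 72 h; on this read-out higher numbers stand for weaker inhibition and lower numbers for stronger inhibition. Compound 3 `O=C1c2c[n+]([O-])c3ccccc3c2C(=O)c2c1c1ccccc1n2Cc1cn([C@H]2C[C@H](O)[C@@H](CO)O2)nn1` gives 390 nM, and compound 2 `CCCCN1CCN(CCCCn2c3c(c4ccccc42)C(=O)c2c[n+]([O-])c4ccccc4c2C3=O)CC1` gives 2150 nM. Among the three numbers, compound 1 stands second highest: compound 3 lies nearest to it, within the scatter, while compound 2 lies furthest, beyond it.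

Compound 4 `O=C1c2c[n+]([O-])c3ccccc3c2C(=O)c2c1c1ccccc1n2CCN1CCCCC1` has not yet been measured. It differs from compound 1 by piperidin-1-yl in place of 3-(dimethylamino)propyl on a saturated chain carbon, two bonds along the chain from an aromatic nitrogen.

Going by the values given here, only one measured step bears on this change, and it does so loosely: a 3.8-fold higher number from compound 1 to compound 2 (0.58 log units; beyond the scatter), where a ring amine replaced an open-chain amine on a saturated chain, though on a longer chain than here. That step was modest. The change to compound 4 also shortens the chain, for which the measured compounds give no guidance. A modest weakening or a step within the scatter is therefore expected, with a 1.5-fold higher number from compound 1 to compound 4 (0.18 log units; within the scatter) as the expected step. Compound 4 is estimated at 850 nM, with a range from 300 nM to 2400 nM.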

Compound 4, half-maximal inhibitory concentration: 180 nM
Estimate against measurement, compound 4: 4.7-fold (0.67 log units) above, outside the stated range (below it).
By their numbers in this assay, from the lowest: compound 4; then compounds 3 and 1 (each within the scatter of the next); then compound 2.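

In this assay, a ring amine on the chain at the aromatic nitrogen does not by itself bring a higher number: the earlier step to a ring amine went upward, but the move to piperidin-1-yl gives a 3.1-fold lower number from compound 1 to compound 4 (0.49 log units; beyond the scatter), a modest step in the opposite direction, so compound 4 goes against any reading of ring amines as weaker than open-chain ones. Among the ring amines, the change is larger still, with a 12-fold lower number from compound 2 to compound 4 (1.08 log units; beyond the scatter), a large step in which the 2-(4-butylpiperazin-1-yl)ethyl portion gives way to piperidin-1-yl, showing that this position responds strongly to what the chain carries and how far it extends. No measured evidence here explains either step.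

Both steps change the amine and the chain length together, so the compounds shown cannot say how much of either step belongs to the ring and how much to the shorter chain. A 2-(dimethylamino)ethyl group or a 5-(piperidin-1-yl)pentyl group on the aromatic nitrogen would separate the two changes, and a morpholine on the same short chain would ask whether the piperidine ring itself matters.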